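The compounds below may be only part of what the source reports. "The series", "measured", "known", "first", "only" and "open" are said of these compounds alone.

In an ADME assay on the whole organism (Rattus norvegicus) for pharmacokinetics, using cassette dosing, at a dose of 1 mg/kg by the oral route (on this read-out higher numbers stand for higher oral bioavailability and lower numbers for lower oral bioavailability), compound 1 `CC(C)Oc1ccc(/N=c2\[nH]c(=O)n(C[C@@H](C)C(=O)O)c(=O)n2Cc2ccc(Cl)cc2)cc1Cl` gives 108% and compound 2 `Cc1cc(/N=c2\[nH]c(=O)n(C[C@H](C)C(=O)O)c(=O)n2Cc2ccc(Cl)cc2)ccc1OC(C)C` gives 102%, two values within the usual scatter of each other. Compound 3 `C[C@@H](Cn1c(=O)[nH]/c(=N\c2ccc(Oc3cccc(F)n3)cc2)n(Cc2ccc(Cl)cc2)c1=O)C(=O)O`, at 60%, lies beyond the scatter below compound 1. Compound 1 thus belongs to the upper pair of these numbers, together with compound 2.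

Compound 4 `CC(C)Oc1ccc(/N=c2\[nH]c(=O)n(CC(C)(C)C(=O)O)c(=O)n2Cc2ccc(Cl)cc2)cc1Cl` differs from compound 1 in one place: 1-carboxy-1-methylethyl in place of 1-carboxyethyl on a saturated chain carbon bound to an aromatic nitrogen. For the measured compounds named here, no measured pair shows this change, so the expectation is uncertain: no shift beyond the scatter in this assay. The estimated step of a number 8 percentage points lower from compound 1 to compound 4 (within the scatter) is therefore small. For compound 4 the expected value is 100%, within an estimated range of 70% to 125%.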

Compound 4, oral bioavailability: 85.3%
The estimate for compound 4 lay 14.7 percentage points above the measured number, and the stated range covers the measured number.
By their numbers in this assay, from the lowest: compound 3; then compound 4; then compounds 2 and 1 (each within the scatter of the next).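

In this assay, this position proves sensitive to a small change: 1-carboxy-1-methylethyl in place of 1-carboxyethyl gives a number 22.7 percentage points lower from compound 1 to compound 4 (beyond the scatter). The group that leaves carries a defined stereocentre and the group that enters has none, so this single step cannot separate the loss of the stereocentre from the added methyl. No measurement shown here explains the step. On these data alone, it remains open how oral bioavailability would respond to a longer chain at this place, or to an amide in place of the carboxylic acid.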